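Growing a Methyl into a Methylphenyl Group

The source may hold more compounds than are shown below. What is called first, only, known or untested is meant among the compounds shown, and "the series" means these compounds.

Of the compounds shown here, three have been tested in an assay on isolated protein for inhibition of high affinity 3',5'-cyclic-AMP phosphodiesterase 7A (Homo sapiens), read by scintillation proximity assay and cAMP accumulation, with a stated time of 20 min, tested at 10 uM; on this read-out lower numbers stand for less inhibition and higher numbers for more inhibition at the one concentration tested (going by the name of the read-out). Compound 1 `CCOc1cc(C(=O)OCc2ccc(-c3ccc(Cl)cc3Cl)o2)cc(OCC)c1OCC` gives 3.7%, compound 2 `CCOc1cc(C(=O)OCc2ccc(-c3ccc(C)cc3)o2)cc(OCC)c1OCC` gives 16.4%, and compound 3 `COc1cc(COC(=O)c2ccc(C)o2)cc(OC)c1OC` gives -9.9%. Compound 3 thus stands lowest of the three, with compound 1 nearest to it and compound 2 furthest away, both separated from it by more than the usual scatter.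

Compound 4 `COc1cc(COC(=O)c2ccc(-c3ccc(C)cc3)o2)cc(OC)c1OC` is built from compound 3 by one change: 4-methylphenyl in place of methyl on an aromatic carbon. The group enters on an aromatic carbon of a five-membered aromatic ring with 1 oxygen.

For the measured compounds named here, no measured pair swaps a methyl for a 4-methylphenyl directly. Going by the values given here, the only measured step touching this part of the molecule is a number 12.7 percentage points higher from compound 1 to compound 2 (beyond the scatter), which shows that a 4-methylphenyl on the five-membered ring can go with a higher number than another aromatic group there. Compound 2, which also carries a 4-methylphenyl, gives the highest number seen, while the shared core of compound 3 and compound 4 differs from that of compound 2 in the ester direction and in the smaller alkoxy groups, so the transfer is uncertain.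

The step of a number 17.9 percentage points higher from compound 3 to compound 4 (beyond the scatter) is therefore expected to be a modest rise. Compound 4 is estimated to give 8% in this assay, within a range from -8% to 24%.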

Compound 4, a percentage reported as inhibition, at one concentration (the size of the read-out at that concentration, not a potency): 30.7%
For compound 4 the middle estimate is 22.7 percentage points below the measured one; the measured number lies above the stated range.
By their numbers in this assay, from the lowest: compound 3; then compound 1; then compound 2; then compound 4.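

Placing 4-methylphenyl in place of methyl, on the aromatic carbon next to the ring oxygen, gives in this assay a large rise: a number 40.6 percentage points higher from compound 3 to compound 4 (beyond the scatter). The earlier step, a number 12.7 percentage points higher from compound 1 to compound 2 (beyond the scatter), only exchanged one aromatic group for another, whereas this one shows that adding a six-membered aromatic ring where a lone methyl stood can raise the inhibition read at this position, at least on the shared core of compound 3 and compound 4. No measurement shown here explains the size of this rise.

As far as these compounds go, what remains open is which part of the new group goes with the rise: a plain phenyl, a simple ethyl or a piperidine at the same carbon would help separate the effect of the ring from that of its methyl. From the compounds shown here alone, it is also open whether the 2,4-dichlorophenyl group would give a lower number than 4-methylphenyl on this core too, and how any of these single-concentration readings would translate into a true potency.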